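The compounds below may be only part of what the source reports. "The series", "measured", "known", "first", "only" and "open" are said of these compounds alone.

In an ADME assay on MT4 cells (Homo sapiens) for cytotoxicity, read by MTT assay, with a stated time of 96 h (a higher number here means that more compound is tolerated, a lower number that less compound is tolerated), compound 1 `COc1ccc(-c2nc3cc(/C(C)=N/O)ccc3[nH]2)c(OC)c1` gives >= 100000 nM, which is a limit of the assay and not a number. Going by the values given here, compound 2 `COc1ccc(-c2nc3cc(/C(C)=N/NC(N)=O)ccc3[nH]2)c(OC)c1` gives 21000 nM, the only actual number so far. Compound 3 `COc1ccc(-c2nc3cc(/C(C)=N/NC(N)=O)ccc3n2C2CCCCC2)c(OC)c1` keeps everything in compound 2 except one place, with cyclohexyl in place of hydrogen on an aromatic nitrogen. Among the compounds with values here, the only measured step, an at least 4.7-fold lower number from compound 1 to compound 2 (0.67 log units; beyond the scatter), put ureido in place of hydroxy on a double-bonded nitrogen. That is a different place from the new change, so this step guides only loosely, but it makes a lower number more likely than a higher one for compound 3. The expected change is modest, with wide uncertainty: a 2.1-fold lower number from compound 2 to compound 3 (0.32 log units; beyond the scatter). Compound 3 is estimated at 10000 nM in this assay, with an expected range from 3000 nM to 40000 nM.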

Compound 3, half-maximal cytotoxic concentration: 23000 nM
Compound 3: the middle estimate sits 2.3-fold (0.36 log units) below what was measured; measured number inside the range.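

In this assay, cyclohexyl in place of hydrogen on an aromatic nitrogen gives a 1.1-fold higher number from compound 2 to compound 3 (0.04 log units; within the scatter). Compounds 2 and 3 therefore cannot be told apart here, so with the ureido group in place, this nitrogen can carry a six-membered carbon ring instead of its hydrogen without a measurable shift in the number, unlike the earlier change at the double-bonded nitrogen, which gave a step beyond the scatter. Nothing shown here explains why this change leaves the number where it was.

This rests on a single group at a single position, so it does not show whether any other group would behave the same way. A methyl group, a longer chain or a chain ending in an amine on this nitrogen might give a different number.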